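The compounds below may be only part of what the source reports. "The series", "measured", "known", "first", "only" and "open" are said of these compounds alone.

Three compounds carry numbers in a functional assay on DU-145 cells (Homo sapiens) for cytotoxicity, read by MTT assay, with a stated time of 72 h; on this read-out higher numbers stand for an effect only at larger amounts of compound and lower numbers for an effect already at smaller amounts. Compound 1 `COc1ccc(Nc2cc(C3CCCCC3)oc(=O)c2)cc1` gives 8.61 uM, the highest of the three. Compound 2 `COc1ccc(Nc2cc(-c3ccc4ccccc4c3)oc(=O)c2)cc1` gives 0.15 uM, and compound 3 `COc1ccccc1Nc1cc(-c2ccccc2)oc(=O)c1` gives 0.37 uM; both of these gaps from compound 1 lie beyond the scatter, so compound 1 is the least potent of the measured set. Compound 4 `COc1ccc(Nc2cc(C3CCCC3)oc(=O)c2)cc1` has not yet been measured in this assay. It differs from compound 1 in one place: cyclopentyl in place of cyclohexyl on an aromatic carbon. Among the measured compounds shown here, no measured pair differs by a change of this kind, so there is no step to lean on. The expected step from compound 1 to compound 4 is small, in either direction, and not beyond the scatter: a 1.2-fold higher number from compound 1 to compound 4 (0.06 log units; within the scatter). Compound 4 is estimated at 10 uM, with a range from 4 uM to 25 uM.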

Compound 4, concentration for half-maximal effect: 5.42 uM
Compound 4: the middle estimate sits 1.8-fold (0.27 log units) above what was measured; low and high end bracket the measured number.
By their numbers in this assay, from the lowest: compound 2; then compound 3; then compounds 4 and 1 (each within the scatter of the next).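

In this assay, among the compounds shown here, cyclopentyl in place of cyclohexyl, on the aromatic carbon next to the ring oxygen, gives a 1.6-fold lower number from compound 1 to compound 4 (0.20 log units; within the scatter) and so provides the first readable step at this position. Between these two non-aromatic rings of carbon only, the change of ring size does not separate the two compounds. No independent evidence bears on this result. Still open, as far as these compounds go, is whether a smaller ring such as cyclopropyl, an open chain such as n-butyl, or a piperidine ring carrying its amine at this position would stay within the same range.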